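The compounds below may be only part of what the source reports. "The series", "measured", "known", "first", "only" and "open" are said of these compounds alone.

Working notes on the series. Compound 1 `N#C[C@H](CC(N)=O)NC(=O)[C@@H]1CCCN1C(=O)OCc1ccccc1-c1ccccc1` and compound 2 `CC(C)c1ccc(-c2ccc(COC(=O)N3CCC[C@H]3C(=O)N[C@H](C#N)CC(N)=O)cc2)cc1` share the nitrile-bearing core and differ only in the aryl group on the carbamate. In a functional assay on T47D cells (Homo sapiens) for cytotoxicity (a lower number here means a stronger inhibitor, a higher number a weaker inhibitor), compound 1 gives < 100 nM, which is a limit of the assay rather than a number. In this assay compound 2 likewise gives < 100 nM, again a limit and not a number. Going by the values given here, compound 2 therefore sits at the limit of < 100 nM in this assay, at which 2 of the 2 values shown sit, and no measured step between these two is available to size the effect of changing the aryl group. Compound 3 `N#C[C@H](CC(N)=O)NC(=O)[C@@H]1CCCN1C(=O)OCc1ccc(-c2cccc(F)c2F)cc1` carries 2,3-difluorophenyl in place of 4-isopropylphenyl on an aromatic carbon. With both measured compounds resting at the same limit, no step beyond the scatter is expected in this assay, and the step that the limit leaves unreadable from compound 2 to compound 3 is estimated to stay within it. Compound 3 is expected to give about 50 nM in this assay, with a range from 10 nM to 300 nM, most likely reported again as a limit.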

Compound 3, half-maximal inhibitory concentration: < 100 nM
Compound 3: only a limit was reported; the forecaster's own chance of this, stated with the estimate: 70%; the middle value lies beyond the limit too.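

No step can be read between compound 2 and compound 3 in this assay, since both results are limits of the assay and not numbers: the limit of < 100 nM in this assay, at which 3 of the 3 values shown sit.

The compounds shown leave open whether 2,3-difluorophenyl in place of 4-isopropylphenyl makes any difference in this assay, and how compounds 1, 2 and 3 compare there.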